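The source may hold more compounds than are shown below. What is called first, only, known or untested is meant among the compounds shown, and "the series" means these compounds.

Measured so far in a functional assay on HeLa cells (Homo sapiens) for antiproliferative activity, read by MTT assay, with a stated time of 48 h; on this read-out higher numbers stand for weaker inhibition and lower numbers for stronger inhibition:
- compound 1 `Cn1c(N)c(-c2nc3ccccc3[nH]2)c2nc(C#N)c(C#N)nc21`: > 50000 nM (a limit of the assay)
- compound 2 `CN1CCN(CCCn2c(N)c(-c3nc4ccccc4[nH]3)c3nc(C#N)c(C#N)nc32)CC1`: 15600 nM

Among the compounds with values here, compound 2 holds the only actual number, 15600 nM. Compound 1 reads > 50000 nM, which is a limit.

Compound 3 `N#Cc1nc2c(-c3nc4ccccc4[nH]3)c(N)n(CCCO)c2nc1C#N` keeps the chain of compound 2 but changes its end group: hydroxy in place of 4-methylpiperazin-1-yl on a saturated chain carbon, three bonds along the chain from an aromatic nitrogen. This places hydroxy in place of 4-methylpiperazin-1-yl on a saturated chain carbon, three bonds along the chain from an aromatic nitrogen.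

Within the data shown here, one measured step bears on this change: an at least 3.2-fold lower number from compound 1 to compound 2 (0.50 log units; beyond the scatter). It lies beyond the scatter, but it starts from a limit, and it brings in the chain and the end group together. The data do not separate the two.

Compound 3 retains the chain but loses the 4-methylpiperazin-1-yl, so part of the gain seen in that step is expected to be lost. A modest move to a higher number, meaning weaker inhibition, is therefore expected in this assay. A reading that gives only a limit is also a real possibility.

The estimated value for compound 3 is 38000 nM, with an expected range of 15000 nM to 100000 nM. The expected change is a 2.4-fold higher number from compound 2 to compound 3 (0.39 log units; beyond the scatter).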

Compound 3, half-maximal inhibitory concentration: > 50000 nM
Compound 3: no number, only a limit; the forecaster's own chance of this, stated with the estimate: 50%; middle value at least 1.3-fold (0.11 log units) from the limit.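

Hydroxy in place of 4-methylpiperazin-1-yl on a saturated chain carbon, three bonds along the chain from an aromatic nitrogen, gives an at least 3.2-fold higher number from compound 2 to compound 3 (0.50 log units; beyond the scatter) in this assay. The value of compound 3, > 50000 nM, is a limit of the assay. With the 3-hydroxypropyl chain in place no number appears, so among these compounds the measurable value of compound 2 goes with the 3-(4-methylpiperazin-1-yl)propyl group and not with a chain of that length alone, while the step from compound 1 to compound 3 cannot be read: the limit of > 50000 nM in this assay, at which 2 of the 3 values shown sit.

Within the data shown here, the true size of the loss on going to hydroxy stays open, and with compound 2 at 15600 nM as the only number, there is not yet a second measured value against which to compare it. Also open, as far as these compounds go, is whether a simple amine such as dimethylamino, a morpholin-4-yl end group or a longer chain carrying 4-methylpiperazin-1-yl would keep, improve or lose activity in this assay.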